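Truncation of compound 1 at a nitrogen on the aromatic ring

A few compounds are considered here, and "the series" means these few. Any claim that something is new, unique, unknown or untested is made for them only; others in the source may bear on it.

Compound 1 `Cc1nn(C)cc1Nc1nc(N)c2c(C#N)c(N3CCC[C@H]3C)n(C)c2n1` stands lowest of the two single numbers in an assay on isolated protein for inhibition of Leucine-rich repeat serine/threonine-protein kinase 2 variant G2019S (Homo sapiens), read by TR-FRET and LanthaScreen, with stated times of 50 min and 30 min, in the presence of a further agent that is not named here (on this read-out lower numbers stand for stronger inhibition and higher numbers for weaker inhibition), where compound 1 gives 30 nM. Its nearest measured neighbour is compound 2 `C[C@@H]1CCCN1c1cc2c(N)ncnc2n1C`, which in this assay gives 6390 nM; that gap lies well beyond the scatter. Compound 3 `Cc1nn(C2CCOC2)cc1Nc1nc(N)c2c(C#N)c(N3CCC[C@H]3C)n(C)c2n1` has several entries: in this assay compound 3 gives 12 nM; 28 nM (2 entries), and the spread of those repeats the several entries of compound 3 in this assay, 12 nM; 28 nM (2 entries) shows how far repeated measurements of this kind move about.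

Compound 4 `C[C@@H]1CCCN1c1c(C#N)c2c(N)nc(N)nc2n1C` is not yet measured. It differs from compound 1 by hydrogen in place of 1,3-dimethyl-1H-pyrazol-4-yl on a nitrogen on an aromatic ring. Going by the values given here, no step between two measured compounds matches this change; compound 2 shows only what the shared core gives when both this group and the nitrile are absent. Because compound 2 sits at 6390 nM against compound 1 at 30 nM, a large step toward weaker inhibition is expected, an 83-fold higher number from compound 1 to compound 4 (1.92 log units; beyond the scatter), though smaller than the gap to compound 2. Compound 4 is expected to give 2500 nM in this assay, within a range of 600 nM to 10000 nM.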

Compound 4, half-maximal inhibitory concentration: 217 nM
Beside the measured number, compound 4's estimate is 12-fold (1.06 log units) above it, and the stated range ends above it.
By their numbers in this assay, from the lowest: compound 1; then compound 4; then compound 2.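

Going by these compounds alone, replacing 1,3-dimethyl-1H-pyrazol-4-yl by hydrogen on a nitrogen on an aromatic ring gives a 7.2-fold higher number from compound 1 to compound 4 (0.86 log units; beyond the scatter) in this assay, the first step that can be read at a single place. The group therefore adds to inhibition but is not essential for it: compound 4, left with a plain amino group, still gives 217 nM. The step is larger than the movement among repeated measurements of one compound: the several entries of compound 3 in this assay, 12 nM; 28 nM (2 entries)

The compounds shown leave open whether a simple phenyl ring or a short alkyl chain on this nitrogen would give a number nearer to that of compound 1 or to that of compound 4. They also leave open what the nitrile alone contributes, as compound 2 differs from compound 4 in more than one place.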